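This account rests on a few compounds, and the source may have more. Where it says the series, first, only, none or still open, it means among the compounds named here.

Three compounds built on a shared core were tested in an ADME assay on Huh-7 cells (Homo sapiens) for cytotoxicity, with a stated time of 72 h; a lower number here means that less compound is tolerated, a higher number that more compound is tolerated: compound 1 `CC(C)CCn1nc(-c2cccs2)c(O)c(C2=NS(=O)(=O)c3cc(S(C)(=O)=O)ccc3N2)c1=O`, compound 2 `CC(C)CCn1nc(-c2cccs2)c(O)c(C2=NS(=O)(=O)c3cc(S(N)(=O)=O)ccc3N2)c1=O` and compound 3 `CC(C)CCn1nc(-c2ccccc2)c(O)c(C2=NS(=O)(=O)c3cc(NS(C)(=O)=O)ccc3N2)c1=O`. For compound 1 the entry reads "not determined" (no result reported). Compound 2 gives > 33000 nM, which is a limit of the assay and not a number. Compound 3 gives > 1000 nM, which is also only a limit. Compound 4 `CC(C)CCn1nc(C2CCC2)c(O)c(C2=NS(=O)(=O)c3cc(NS(C)(=O)=O)ccc3N2)c1=O` carries cyclobutyl in place of phenyl on an aromatic carbon. For the measured compounds named here, no measured step shows the effect of such a change, and the data hold no exact value, so the expectation is tentative: a move towards more compound tolerated, with an expected step that the limit leaves unreadable from compound 3 to compound 4. For compound 4 the estimated value is 10000 nM, with an expected range from 2000 nM to 40000 nM.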

Compound 4, half-maximal cytotoxic concentration: > 33000 nM
Compound 4 gave a limit, no number; the forecaster's own chance of this, stated with the estimate: 70%; at least 3.3-fold (0.51 log units) between middle value and limit.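

Compound 3 and compound 4 both gave only limits, so the step between them cannot be read. The compounds shown leave open how much cyclobutyl in place of phenyl changes the amount of compound tolerated.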